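Cyclohexylmethyl for 3-Cyanophenyl in a Bombesin Receptor Agonist Series

The source may hold more compounds than are shown below. What is called first, only, known or untested is meant among the compounds shown, and "the series" means these compounds.

compound 1, `CC(C)(C)Cc1cnc(CCc2ccc(-c3ccccc3C(=O)O)cc2)[nH]1`, gives 106 nM in an in vitro functional assay on cells for agonist activity at Bombesin receptor subtype-3 (Homo sapiens), read by luminescence and calcium flux; a higher number here means that more compound is needed for the effect, a lower number that less compound is needed.
compound 2, `N#Cc1cccc(Cc2cnc(CCc3ccc(-c4ccccc4C(=O)O)cc3)[nH]2)c1`, gives 812 nM in this assay.

Among these two numbers compound 2 stands highest, and its nearest neighbour is compound 1. Among the compounds with values here, the only measured step, a 7.7-fold higher number from compound 1 to compound 2 (0.88 log units; beyond the scatter), is what bears on the next change. Compound 3, `O=C(O)c1ccccc1-c1ccc(CCc2ncc(CCC3CCCCC3)[nH]2)cc1`, differs from compound 2 by cyclohexylmethyl in place of 3-cyanophenyl on a saturated chain carbon bound to an aromatic carbon. Because that earlier step, a 7.7-fold higher number from compound 1 to compound 2 (0.88 log units; beyond the scatter), ran from a saturated chain group to an aromatic one, and the new change goes back from an aromatic ring to a non-aromatic ring of carbon only, the number in this assay is expected to fall again, by an estimated 5.1-fold lower number from compound 2 to compound 3 (0.71 log units; beyond the scatter). Compound 3 is therefore estimated at 160 nM, with a range from 50 nM to 500 nM.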

Compound 3, half-maximal effective concentration: 642 nM
The estimate for compound 3 lay 4.0-fold (0.60 log units) below the measured number, outside the stated range (above it).
By their numbers in this assay, from the lowest: compound 1; then compounds 3 and 2 (each within the scatter of the next).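

In this assay, cyclohexylmethyl in place of 3-cyanophenyl on a saturated chain carbon bound to an aromatic carbon gives a 1.3-fold lower number from compound 2 to compound 3 (0.10 log units; within the scatter), so leaving the aromatic ring and its nitrile for a non-aromatic ring of carbon only produces no change beyond the scatter. Set against tert-butyl, the same group gives a 6.1-fold higher number from compound 1 to compound 3 (0.78 log units; beyond the scatter), which shows that a non-aromatic group at this position does not by itself bring back the number of compound 1. Nothing available explains this result.

Still open, as far as these compounds go, is how a plain phenyl without the nitrile would read at this position, and how a cyclohexyl ring carrying an amine would compare.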